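The Same Phenyl Swap Tried on a Second Core

A few compounds are considered here, and "the series" means these few. Any claim that something is new, unique, unknown or untested is made for them only; others in the source may bear on it.

Of the compounds shown here, three have been measured and a fourth has not. Compound 1 `Cc1ccc(-c2csc(NC(=O)COc3ccccc3C)n2)cc1` and compound 2 `Cc1ccc(-c2csc(NC(=O)COc3ccc(F)cc3F)n2)cc1` share one core; compound 3 `Cc1ccccc1OCC(=O)Nc1nc(-c2ccc(Br)cc2)cs1` and compound 4 `O=C(COc1ccc(F)cc1F)Nc1nc(-c2ccc(Br)cc2)cs1` share another. In a functional assay on MDA-MB-468 cells (Homo sapiens) for cytotoxicity, read by trypan blue exclusion, with a stated time of 48 h (on this read-out higher numbers stand for weaker inhibition and lower numbers for stronger inhibition), compound 1 gives 51700 nM, compound 2 gives 10200 nM, and compound 3 gives 44500 nM.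

Compound 1 and compound 2 differ in one place: 2,4-difluorophenyl in place of 2-methylphenyl on an oxygen on a saturated carbon. This change made a step of a 5.1-fold lower number from compound 1 to compound 2 (0.70 log units; beyond the scatter) in this assay, the only clear movement among the measured numbers. Compound 1 and compound 3 differ at the core: bromo in place of methyl on an aromatic carbon. That step, a 1.2-fold lower number from compound 1 to compound 3 (0.07 log units; within the scatter), stays within the scatter, so the two cores read as roughly interchangeable on what is known.

Compound 4 carries the same change relative to compound 3 as compound 2 carries relative to compound 1: 2,4-difluorophenyl in place of 2-methylphenyl on an oxygen on a saturated carbon. The place where the change sits is described in identical terms in both pairs, so it is the same change, made twice, once on each core.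

The expectation rests on one earlier step only. Because the step of a 5.1-fold lower number from compound 1 to compound 2 (0.70 log units; beyond the scatter) lowered the number clearly, and because the core difference a 1.2-fold lower number from compound 1 to compound 3 (0.07 log units; within the scatter) hardly moved it, a step of about the same size is expected from compound 3 to compound 4, namely a 4.9-fold lower number from compound 3 to compound 4 (0.69 log units; beyond the scatter). Compound 4 is therefore estimated at 9000 nM in this assay, plausibly lying between 3500 nM and 25000 nM.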

Compound 4, half-maximal inhibitory concentration: 44700 nM
Compound 4: the middle estimate sits 5.0-fold (0.70 log units) below what was measured, outside the stated range (above it).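

In this assay, the swap to 2,4-difluorophenyl on the second core gave a 1.0-fold higher number from compound 3 to compound 4 (0.00 log units; within the scatter), so the clear drop seen on the first core did not carry over: the same change on two cores in this assay, a 5.1-fold lower number (0.70 log units; beyond the scatter) from compound 1 to compound 2 and a 1.0-fold higher number (0.00 log units; within the scatter) from compound 3 to compound 4, 5.1-fold (0.71 log units) apart, beyond the scatter of two such steps. Read from the other side, bromo in place of methyl on an aromatic carbon mattered little with 2-methylphenyl present, yet with 2,4-difluorophenyl present it gave a 4.4-fold higher number from compound 2 to compound 4 (0.64 log units; beyond the scatter): the same change on two cores in this assay, a 1.2-fold lower number (0.07 log units; within the scatter) from compound 1 to compound 3 and a 4.4-fold higher number (0.64 log units; beyond the scatter) from compound 2 to compound 4, 5.1-fold (0.71 log units) apart, beyond the scatter of two such steps. Among the compounds shown here, these four compounds therefore show that the two changes do not act independently here, so the effect of one depends on which group is present at the other place, but they do not show why, and with only one pair on each core they give no general rule for the series.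

From the compounds shown here alone, it remains open whether the dependence is specific to methyl and bromo, or whether chloro or methoxy on that aromatic carbon would behave like either of them when paired with the 2,4-difluorophenyl group. Going by these compounds, it is also open how a plain phenyl on the oxygen would read on each core, and whether any such group would carry from one core to the other.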